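Ethoxy for methylamino on the carbonyl carbon

The source may report more compounds than this note shows. Statements on the series, on what has been measured and on what is new or still open speak of the compounds shown alone.

Compound 2 `CNC(=O)/C=C/c1ccncc1-c1ccc2ccccc2c1`: 12.4 nM
Compound 1 `Cn1ncc2cc(-c3cnccc3/C=C/C(=O)N3CCOCC3)ccc21`: 356 nM

Of the compounds shown here, two have been measured in an assay on a protein complex for inhibition of CDK8/Cyclin C (Homo sapiens), with a stated time of 1 h; a lower number here means a stronger inhibitor, a higher number a weaker inhibitor. Compound 2 gives 12.4 nM and stands lowest of the two numbers; compound 1 gives 356 nM, and the gap between the two lies beyond the scatter. For the measured compounds named here, these two differ at more than one place, so no step between measured compounds is available as a guide.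

Compound 3 `CCOC(=O)/C=C/c1ccncc1-c1ccc2ccccc2c1` has not yet been measured. It differs from compound 2 at one place:

ethoxy in place of methylamino on a carbonyl carbon

Cut one bond further out, the exchange reads methylcarbamoyl to ethoxycarbonyl. Going by the values given here, no measured pair shows this exchange, so nothing in the numbers so far fixes its size or direction. The step expected here is an 8.1-fold higher number from compound 2 to compound 3 (0.91 log units; beyond the scatter), a moderate rise in the number, beyond the scatter. For compound 3 the estimated value in this assay is 100 nM, with a range from 25 nM to 600 nM.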

Compound 3, half-maximal inhibitory concentration: 53.3 nM
Beside the measured number, compound 3's estimate is 1.9-fold (0.27 log units) above it; low and high end bracket the measured number.
By their numbers in this assay, from the lowest: compound 2; then compound 3; then compound 1.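

The first step read at this position in this assay is a 4.3-fold higher number from compound 2 to compound 3 (0.63 log units; beyond the scatter), for ethoxy in place of methylamino on a carbonyl carbon. The rise is modest but beyond the usual scatter, so the exchange does register at this position. Even without the hydrogen-bond donor of methylamino, compound 3 gives 53.3 nM, so the ester keeps measurable inhibition in this assay. No measurement on hand accounts for the size of this step.

This single pair does not separate the loss of the amide hydrogen from the gain of the ethoxy oxygen and its longer chain, and dimethylamino on the same carbonyl carbon would pull these apart. Going by these compounds, how a free carboxylic acid or a propoxy group would fare at this position also remains open.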